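The compounds below may be only part of what the source reports. "The series", "measured", "known", "first", "only" and "open" are said of these compounds alone.

Measured so far in a functional assay on NB-4 cells (Homo sapiens) for inhibition, read by XTT assay, with a stated time of 48 h; on this read-out lower numbers stand for stronger inhibition and higher numbers for weaker inhibition:
compound 1 `CCC(/C=C(\COC(C)=O)C(=O)c1ccc(OC)cc1)CC` gives 9500 nM.
Compound 2 `COc1ccc(C(=O)/C(=C/c2ccccc2F)CCOC(C)=O)cc1` reaches only a limit, > 100000 nM.
Compound 3 `CCC(/C=C(\CCOC(C)=O)C(=O)c1ccc(OC)cc1)CC` gives 91100 nM.

Compound 3 holds the higher of the two numbers in this assay; its nearest neighbour is compound 1, with a 9.6-fold higher number from compound 1 to compound 3 (0.98 log units; beyond the scatter). The value of compound 2 is the limit of > 100000 nM in this assay, at which 1 of the 3 values shown sits.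

Compound 4 `COc1ccc(C(=O)/C(=C/c2ccc([N+](=O)[O-])cc2)CCOC(C)=O)cc1` differs from compound 3 by 4-nitrophenyl in place of pentan-3-yl on a double-bonded chain carbon bound to a double-bonded chain carbon. Going by the values given here, the one measured step at this place is an at least 1.0-fold lower number from compound 2 to compound 3 (0.04 log units; that floor lies within the scatter), which runs from 2-fluorophenyl to pentan-3-yl and rests on a limit. Returning to an aromatic group is therefore expected to move the number upward, if anywhere, and the step of a 1.6-fold higher number from compound 3 to compound 4 (0.22 log units; within the scatter) is the expected size. Compound 4 is estimated at 150000 nM, between 40000 nM and 600000 nM, with a fair chance that only a limit is reported.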

Compound 4, half-maximal inhibitory concentration: > 100000 nM
Compound 4 ended at the assay's limit (the forecaster's own chance of this, stated with the estimate: 55%); the middle value lies beyond the limit too.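

The change from pentan-3-yl to 4-nitrophenyl gives an at least 1.0-fold higher number from compound 3 to compound 4 (0.04 log units; that floor lies within the scatter), so this floor shows no readable shift in either direction. The step from compound 2 to compound 4 cannot be read, since both values are limits. Two different aromatic groups at this place, 2-fluorophenyl and 4-nitrophenyl, now end the same way: the limit of > 100000 nM in this assay, at which 2 of the 4 values shown sit.

Open, as far as these compounds go, is whether an amine or a carboxylic acid at this place would give a number below the limit. Also open, from the compounds shown here alone, is whether 4-nitrophenyl would do so with the shorter acetoxy chain of compound 1.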